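The compounds below may be only part of what the source reports. "The series", "measured", "known", "first", "only" and "open" are said of these compounds alone.

Measured so far in a functional assay on Jurkat cells (Homo sapiens); a lower number here means a stronger inhibitor, a higher number a weaker inhibitor:
- compound 1 `Cc1ccccc1CNC(=O)C(=O)N[C@@H](C)C(=O)N[C@@H](CC(=O)O)C(=O)COc1c(F)c(F)cc(F)c1F`: 52 nM
- compound 2 `Cc1cccc(CNC(=O)C(=O)N[C@@H](C)C(=O)N[C@@H](CC(=O)O)C(=O)COc2c(F)c(F)cc(F)c2F)c1C`: 102 nM
- compound 3 `C[C@H](NC(=O)C(=O)NCc1cccc(Cl)c1Cl)C(=O)N[C@@H](CC(=O)O)C(=O)COc1c(F)c(F)cc(F)c1F`: 76 nM

Against compound 1 and compound 2, compound 3 (76 nM) lies within the scatter of both. Compound 4 `C[C@H](NC(=O)C(=O)NCc1c(Cl)cccc1Cl)C(=O)N[C@@H](CC(=O)O)C(=O)COc1c(F)c(F)cc(F)c1F` differs from it by 2,6-dichlorophenyl in place of 2,3-dichlorophenyl on a saturated chain carbon bound to an amide-type nitrogen with 2,6-dichlorophenyl in place of 2,3-dichlorophenyl on a saturated chain carbon bound to an amide-type nitrogen. Three measured steps at this group bear on the change: a 2.0-fold higher number from compound 1 to compound 2 (0.29 log units; within the scatter) and a 1.5-fold higher number from compound 1 to compound 3 (0.16 log units; within the scatter) and a 1.3-fold lower number from compound 2 to compound 3 (0.13 log units; within the scatter) all stay within the scatter. For the measured compounds named here, no measured compound carries the 2,6-dichlorophenyl group. In this assay the expected step is a 1.0-fold lower number from compound 3 to compound 4 (0.01 log units; within the scatter) with no direction and nothing beyond the scatter. The estimate for compound 4 is 75 nM with an expected range from 32 nM to 175 nM overall.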

Compound 4, half-maximal inhibitory concentration: 110 nM
Estimate against measurement, compound 4: 1.5-fold (0.17 log units) below; measured number inside the range.
By their numbers in this assay, from the lowest: compounds 1, 3, 2 and 4 (each within the scatter of the next, the first and the last beyond it).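

In this assay, 2,6-dichlorophenyl in place of 2,3-dichlorophenyl on this saturated chain carbon stays within the scatter (a 1.4-fold higher number from compound 3 to compound 4 (0.16 log units; within the scatter)), and so does its replacement of 2,3-dimethylphenyl (a 1.1-fold higher number from compound 2 to compound 4 (0.03 log units; within the scatter)). Only the change from 2-methylphenyl gives a step beyond the scatter at this position, and a modest one (a 2.1-fold higher number from compound 1 to compound 4 (0.33 log units; beyond the scatter)). No supporting data offer an explanation for these steps.

Still open, as far as these compounds go, is how an unsubstituted phenyl, a 2-chlorophenyl or a 2-methoxyphenyl group would compare at this place with the 2-methylphenyl group of compound 1.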